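Isopentyloxy to 2-ethylbutoxy: notes on the chain series

The compounds below may be only part of what the source reports. "The series", "measured", "known", "first", "only" and "open" are said of these compounds alone.

In a functional assay on NUGC-3 cells (Homo sapiens) for antiproliferative activity, read by sulforhodamine B assay (a higher number here means a weaker inhibitor of growth, a lower number a stronger inhibitor of growth), compound 3 `CC(C)CCOc1cccc(O)c1C(=O)/C=C/c1ccc(O)cc1` gives 12400 nM, the higher of the two true numbers in the series, while compound 1 `CC(C)CCCOc1cccc(O)c1C(=O)/C=C/c1ccc(O)cc1` gives 3520 nM. Compound 2 `CC(C)=CCOc1cccc(O)c1C(=O)/C=C/c1ccc(O)cc1` gives > 30000 nM, which is a limit of the assay and not a number.

Compound 4 `CCC(CC)COc1cccc(O)c1C(=O)/C=C/c1ccc(O)cc1` carries pentan-3-yl in place of isobutyl on a saturated chain carbon bound to an oxygen on an aromatic ring; the same difference reads isopentyloxy to 2-ethylbutoxy.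

Going by the values given here, the closest precedent is a 3.5-fold higher number from compound 1 to compound 3 (0.55 log units; beyond the scatter), where isopropyl replaces isobutyl on the chain, so in this single pair the chain with fewer carbons carries the higher number. Two further steps, an at least 8.5-fold higher number from compound 1 to compound 2 (0.93 log units; beyond the scatter) and an at least 2.4-fold lower number from compound 2 to compound 3 (0.38 log units; beyond the scatter), concern the unsaturated chain of compound 2 and bear only weakly on a change between saturated groups. Among the compounds with values here, no measured compound has branching at this chain carbon, so the precedent transfers only loosely.

A modest move towards a lower number in this assay is therefore expected, and the estimated change is a 2.3-fold lower number from compound 3 to compound 4 (0.35 log units; beyond the scatter). For compound 4 the estimated value is 5500 nM, with an expected range of 1800 nM to 17000 nM.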

Compound 4, concentration for 50% growth inhibition: 1960 nM
Compound 4: middle estimate off by 2.8-fold (0.45 log units), on the high side; low and high end bracket the measured number.
By their numbers in this assay, from the lowest: compounds 4 and 1 (each within the scatter of the next); then compound 3. At a limit, above all of these: compound 2.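

In this assay, going by these compounds alone, branching at the saturated chain carbon bound to an oxygen on an aromatic ring, a feature absent from the earlier compounds, is compatible with growth inhibition: pentan-3-yl in place of isobutyl gives a 6.3-fold lower number from compound 3 to compound 4 (0.80 log units; beyond the scatter). Pentan-3-yl in place of isopentyl gives a 1.8-fold lower number from compound 1 to compound 4 (0.25 log units; within the scatter), so the branched 2-ethylbutoxy chain and the unbranched-at-this-carbon chain of the four-carbon isopentyl group cannot be ordered in this series. Pentan-3-yl in place of 2-methylprop-1-en-1-yl gives an at least 15-fold lower number from compound 2 to compound 4 (1.18 log units; beyond the scatter), and this step rests on a limit of the assay and not a number: the limit of > 30000 nM in this assay, at which 1 of the 4 values shown sits.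

Still open, from the compounds shown here alone, is whether the low end of the series can be moved further by a longer chain such as hexyloxy or by a cyclohexylmethoxy group, or whether 2-ethylbutoxy and the chain of compound 1 mark a floor for saturated groups at this position. Also open, going by these compounds, is how a polar end on the chain, such as an amine or a carboxylic acid, would read against these saturated chains.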